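The source may hold more compounds than are shown below. What is called first, only, known or untested is meant among the compounds shown, and "the series" means these compounds.

Compounds measured so far: compound 1 `COCCCOc1nc(C(C)(C)C)ccc1CNC(=O)C(C)c1ccc(NS(C)(=O)=O)c(F)c1`, compound 2 `CCCCSc1nc(C(C)(C)C)ccc1CNC(=O)C(C)c1ccc(NS(C)(=O)=O)c(F)c1` and compound 3 `CCCCCSc1nc(C(C)(C)C)ccc1CNC(=O)C(C)c1ccc(NS(C)(=O)=O)c(F)c1`.

In an assay on cells for antagonist activity at transient receptor potential cation channel subfamily V member 1 (Homo sapiens), read by FLIPR and calcium flux, with a stated time of 6 min (a higher number here means a weaker inhibitor, a lower number a stronger inhibitor), compound 1 gives 5.6 nM, compound 2 gives 3.2 nM and compound 3 gives 3.1 nM. Compound 3 has the lowest of the three numbers, but it sits within the scatter of both others: a 1.0-fold lower number from compound 2 to compound 3 (0.01 log units; within the scatter) and a 1.8-fold lower number from compound 1 to compound 3 (0.26 log units; within the scatter).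

Compound 4 `CC(C(=O)NCc1ccc(C(C)(C)C)nc1C1CCCCC1)c1ccc(NS(C)(=O)=O)c(F)c1` differs from compound 3 in one place: cyclohexyl in place of pentylsulfanyl on an aromatic carbon. Neither measured step tries a ring at this position; the steps known here, a 1.8-fold lower number from compound 1 to compound 2 (0.24 log units; within the scatter) and a 1.0-fold lower number from compound 2 to compound 3 (0.01 log units; within the scatter), show that swapping or lengthening the chain at this carbon left this assay essentially unchanged. Compound 4 is therefore expected to stay close to compound 3, with a step of about a 1.6-fold higher number from compound 3 to compound 4 (0.21 log units; within the scatter) estimated. Compound 4 is estimated at 5 nM, within 1.5 nM to 16 nM.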

Compound 4, inhibition constant: 3.1 nM
The estimate for compound 4 lay 1.6-fold (0.21 log units) above the measured number; the range from low to high includes it.
By their numbers in this assay, from the lowest: compounds 3, 4, 2 and 1 (each within the scatter of the next).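

For the compounds shown here, at this carbon next to the ring nitrogen, a ring now appears for the first time: in this assay, cyclohexyl replaces pentylsulfanyl (no change at the digits printed from compound 3 to compound 4 (within the scatter)) and butylsulfanyl (a 1.0-fold lower number from compound 2 to compound 4 (0.01 log units; within the scatter)) with both steps within the scatter. The step from 3-methoxypropoxy also stays within the scatter (a 1.8-fold lower number from compound 1 to compound 4 (0.26 log units; within the scatter)), so among these compounds neither an open chain nor a sulfur or oxygen attached to this carbon is required for a low number. No measurement given here explains this result. The compounds shown leave open whether an amine, a carboxylic acid or a phenyl ring at this carbon would also stay within the scatter.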